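Moving a methoxy group on the aryl ring of compound 3

The source may report more compounds than this note shows. Statements on the series, on what has been measured and on what is new or still open speak of the compounds shown alone.

Among the two numbers in hand, compound 3 `COc1cc(-c2nc3cc(/C=C4\SC(=O)N(Cc5cccc(C)c5)C4=O)ccc3[nH]2)cc(OC)c1OC` stands lowest: in a functional assay on MDA-MB-231 cells (Homo sapiens) for inhibition, read by MTT assay, with a stated time of 48 h (on this read-out lower numbers stand for stronger inhibition and higher numbers for weaker inhibition), compound 3 gives 3260 nM. Compound 1 `COc1cc(OC)c(-c2nc3cc(/C=C4\SC(=O)N(CC(=O)N5CCOCC5)C4=O)ccc3[nH]2)cc1OC` gives 21300 nM, a higher number than compound 3. Compound 2 `COc1cc(OC)c(-c2nc3cc(/C=C4\SC(=O)N(CC(=O)N5CCCCC5)C4=O)ccc3[nH]2)cc1OC` reaches only the limit of > 50000 nM in this assay. Among the compounds with values here, the single measured step, an at least 2.3-fold higher number from compound 1 to compound 2 (0.37 log units; beyond the scatter), concerns a different part of the molecule and ends at a limit (the limit of > 50000 nM in this assay, at which 1 of the 3 values shown sits); it says nothing about the aryl ring. Compound 4 `COc1cc(OC)c(-c2nc3cc(/C=C4\SC(=O)N(Cc5cccc(C)c5)C4=O)ccc3[nH]2)cc1OC` differs from compound 3 by 2,4,5-trimethoxyphenyl in place of 3,4,5-trimethoxyphenyl on an aromatic carbon. Within the data shown here, no measured step covers this change, so no step beyond the scatter is expected, though the uncertainty is wide; the expected step is a 1.4-fold higher number from compound 3 to compound 4 (0.14 log units; within the scatter). Compound 4 is therefore estimated at 4500 nM, within 1500 nM to 15000 nM.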

Compound 4, half-maximal inhibitory concentration: 1780 nM
Compound 4: middle estimate off by 2.5-fold (0.40 log units), on the high side; low and high end bracket the measured number.
By their numbers in this assay, from the lowest: compounds 4 and 3 (each within the scatter of the next); then compound 1. At a limit, above all of these: compound 2.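

Moving from 3,4,5-trimethoxyphenyl to 2,4,5-trimethoxyphenyl on this aromatic carbon gives a 1.8-fold lower number from compound 3 to compound 4 (0.26 log units; within the scatter) in this assay, so this methoxy arrangement does not separate the pair. With 2,4,5-trimethoxyphenyl held fixed, 3-methylphenyl in place of (morpholin-4-yl)carbonyl gives a 12-fold lower number from compound 1 to compound 4 (1.08 log units; beyond the scatter), and in place of (piperidin-1-yl)carbonyl gives an at least 28-fold lower number from compound 2 to compound 4 (1.44 log units; beyond the scatter). That last step starts from a limit of compound 2, not a number: the limit of > 50000 nM in this assay, at which 1 of the 4 values shown sits.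

The compounds shown leave open how a hydroxy group in place of a methoxy group, or a phenyl ring with a single methoxy group, would read here. From the compounds shown here alone, whether the two trimethoxyphenyl patterns stay level with a group other than 3-methylphenyl on the chain carbon also remains open.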